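The source may hold more compounds than are shown below. What is called first, only, known or untested is meant among the compounds shown, and "the series" means these compounds.

Measured in a functional assay on SK-BR-3 cells (Homo sapiens) for cytotoxicity, read by CellTiter-Glo, with a stated time of 72 h; on this read-out lower numbers stand for stronger inhibition and higher numbers for weaker inhibition:
compound 1 `CO[C@H]1C[C@H](C)CC2=C(N3CCC3)C(=O)C=C(NC(=O)/C(C)=C/C=C\[C@H](OC)[C@@H](OC(N)=O)/C(C)=C/[C@H](C)/C1=N\O)C2=O`: 310 nM
compound 2 `C=CCO/N=C1/[C@@H](OC)C[C@H](C)CC2=C(NCCN(C)C)C(=O)C=C(NC(=O)/C(C)=C/C=C\[C@H](OC)[C@@H](OC(N)=O)/C(C)=C/[C@@H]1C)C2=O`: 400 nM
compound 3 `C=CCNC1=C2C[C@@H](C)C[C@H](OC)/C(=N/O)[C@@H](C)/C=C(\C)[C@H](OC(N)=O)[C@@H](OC)/C=C\C=C(/C)C(=O)NC(=CC1=O)C2=O`: 350 nM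

The three values lie within the scatter of one another, so compound 2, at 400 nM, cannot be ranked against compound 1 or compound 3 in this assay.

The next compound to be tested is compound 4 `CO[C@H]1C[C@H](C)CC2=C(NCCN(C)C)C(=O)C=C(NC(=O)/C(C)=C/C=C\[C@H](OC)[C@@H](OC(N)=O)/C(C)=C/[C@H](C)/C1=N\OCC(=O)O)C2=O`. It differs from compound 2 by one change: carboxy in place of vinyl on a saturated chain carbon bound to an oxygen on an unsaturated carbon. In words, carboxy stands in place of vinyl on a saturated chain carbon bound to an oxygen on an unsaturated carbon. The same difference can be read as allyl to carboxymethyl.

Within the data shown here, only one measured step exists, a 1.1-fold higher number from compound 1 to compound 3 (0.05 log units; within the scatter), and it lies within the scatter. That step is an exchange of azetidin-1-yl for allylamino on a double-bonded ring carbon, so it is at another place and sets no size for this change. Among the measured compounds shown here, none of the three measured compounds carries a carboxy group, and the data hold no step at this place. A higher number is nevertheless expected, on the structural change alone, with wide uncertainty. The expected move is a 3.8-fold higher number from compound 2 to compound 4 (0.57 log units; beyond the scatter). Compound 4 is expected at 1500 nM, with an estimated range from 400 nM to 6000 nM.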

Compound 4, half-maximal inhibitory concentration: 2700 nM
Compound 4: middle estimate off by 1.8-fold (0.26 log units), on the low side; measured number inside the range.
By their numbers in this assay, from the lowest: compounds 1, 3 and 2 (each within the scatter of the next); then compound 4.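

In this assay, among these compounds, allyl to carboxymethyl gives a 6.8-fold higher number from compound 2 to compound 4 (0.83 log units; beyond the scatter) and this is the first step that lies beyond the scatter, since the only earlier step was at another place and stayed within it. The read-out therefore does respond to the group on a saturated chain carbon bound to an oxygen on an unsaturated carbon, and carboxy in place of vinyl there goes with weaker inhibition, though this rests on a single pair of compounds and sets no trend. Nothing available explains the size or the direction of this step.

The compounds shown leave open whether the higher number belongs to the carboxylic acid itself, as a methyl ester or a primary amide of the same carboxymethyl group would test, and whether a longer chain ending in the acid would move the number further. They also leave open whether the same exchange gives a step of similar size when azetidin-1-yl or allylamino takes the place of the 2-(dimethylamino)ethylamino group on the double-bonded ring carbon.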